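Halogenated phenyl swap: from compound 3 to compound 4

The source may report more compounds than this note shows. Statements on the series, on what has been measured and on what is new or still open speak of the compounds shown alone.

Three measured members of the series share one core. Compound 1 `COc1ccc(Nc2nc(-c3cccc(F)c3)nc3ccc(F)cc23)cc1` carries a 4-methoxyphenyl on the ring nitrogen, and in a functional assay on MDA-MB-231 cells (Homo sapiens) for cytotoxicity, read by MTT assay, with a stated time of 48 h (a higher number here means a weaker inhibitor, a lower number a stronger inhibitor), compound 1 gives 47300 nM. Compound 2 `Fc1ccc(Nc2nc(-c3cccc(F)c3)nc3ccc(F)cc23)cc1` returns only the assay limit, > 50000 nM, in this assay. Compound 3 `Fc1cccc(-c2nc(Nc3cccc(Cl)c3)c3cc(F)ccc3n2)c1` likewise sits at the limit, > 50000 nM, in this assay. The step of an at least 1.0-fold higher number from compound 1 to compound 2 (0.02 log units; that floor lies within the scatter) and the step of an at least 1.0-fold higher number from compound 1 to compound 3 (0.02 log units; that floor lies within the scatter) are each bounded only from below, and the step that the two limits leave unreadable from compound 2 to compound 3 cannot be read at all, because the limit of > 50000 nM in this assay, at which 2 of the 3 values shown sit, covers both ends of it. Compound 3 therefore stands at the weak end of what the numbers show, with no measured number of its own.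

Compound 4 `Fc1cccc(-c2nc(Nc3ccc(Br)cc3)c3cc(F)ccc3n2)c1` differs from compound 3 by 4-bromophenyl in place of 3-chlorophenyl on a nitrogen on an aromatic ring. Within the data shown here, no measured step covers this exact exchange; the nearest comparisons, the steps from compound 1 and the unreadable step between compound 2 and compound 3, all end at the limit. Compound 4 is expected to behave like compound 3 and to remain at or beyond the limit, so the estimate for compound 4 in this assay is 60000 nM, between 30000 nM and 150000 nM. The expected step that the limit leaves unreadable from compound 3 to compound 4 is accordingly judged to lie within the scatter.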

Compound 4, half-maximal inhibitory concentration: > 50000 nM
Compound 4: no number, only a limit; the forecaster's own chance of this, stated with the estimate: 70%; the middle value lies beyond the limit too.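

In this assay compound 4 returns only a limit of the assay, > 50000 nM. Among these compounds, the one step that can be read, an at least 1.0-fold higher number from compound 1 to compound 4 (0.02 log units; that floor lies within the scatter), is bounded only from below, and the steps to compound 4 from compound 2 and from compound 3 cannot be read. On a nitrogen on an aromatic ring, 4-bromophenyl therefore joins 4-fluorophenyl and 3-chlorophenyl without separating from them, and compound 1 still holds the only measured number in the series, so this third halogenated phenyl adds no readable difference: the limit of > 50000 nM in this assay, at which 3 of the 4 values shown sit.

Whether any group at this position can bring the value clear of the limit stays open, since the compounds shown carry only 4-methoxyphenyl and these halogenated phenyls there. On these data alone, how a phenyl bearing an amine or a carboxylic acid, or a longer chain in place of the phenyl, would read in this assay also stays open, as does any separate contribution of the halogen and of its place on the ring, which change together from compound 3 to compound 4.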